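A few compounds are considered here, and "the series" means these few. Any claim that something is new, unique, unknown or untested is made for them only; others in the source may bear on it.

Compound 3 `O=C1Nc2ccc(Cl)cc2/C1=N/NC(=S)N1CCN(c2ccc(Cl)cc2)CC1` is one of three close analogues sharing a core, differing only in the group on the aromatic ring attached to the ring nitrogen. In a functional assay on HCT-116 cells (Homo sapiens) for inhibition, read by MTT assay, with a stated time of 72 h (on this read-out lower numbers stand for stronger inhibition and higher numbers for weaker inhibition), compound 3 gives 5390 nM. Compound 1 `O=C1Nc2ccc(Cl)cc2/C1=N/NC(=S)N1CCN(c2ccccc2)CC1` gives 3490 nM, and compound 2 `COc1ccc(N2CCN(C(=S)N/N=C3\C(=O)Nc4ccc(Cl)cc43)CC2)cc1` gives 7740 nM, so compound 3 sits at the second highest number of the three, nearest to compound 2 and furthest from compound 1. Compound 4 `O=C1Nc2ccc(Cl)cc2/C1=N/NC(=S)N1CCN(c2ccccc2Cl)CC1` carries 2-chlorophenyl in place of 4-chlorophenyl on an amine nitrogen in a ring. Among the measured compounds shown here, none of the measured steps moves a chloro from one ring position to another; the nearest comparisons are a 1.5-fold higher number from compound 1 to compound 3 (0.19 log units; within the scatter) and a 1.4-fold lower number from compound 2 to compound 3 (0.16 log units; within the scatter), both within the scatter, while a 2.2-fold higher number from compound 1 to compound 2 (0.35 log units; beyond the scatter) is modest. Since every change on this aromatic ring has so far shifted the number only a little, compound 4 is expected to give a 1.1-fold lower number from compound 3 to compound 4 (0.03 log units; within the scatter), a step not beyond the scatter. Compound 4 is therefore estimated at 5000 nM, with a plausible range from 2500 nM to 10000 nM.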

Compound 4, half-maximal inhibitory concentration: 4910 nM
Compound 4: middle estimate off by 1.0-fold (0.01 log units), on the high side; low and high end bracket the measured number.
By their numbers in this assay, from the lowest: compounds 1, 4, 3 and 2 (each within the scatter of the next, the first and the last beyond it).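

Moving the chloro from 4-chlorophenyl to 2-chlorophenyl on the amine nitrogen in the ring is the first change in this series to alter where a group sits rather than which group it is, and in this assay it gives a 1.1-fold lower number from compound 3 to compound 4 (0.04 log units; within the scatter) so this shift of position leaves no readable mark on the number. The other two comparisons read the same way, with a 1.4-fold higher number from compound 1 to compound 4 (0.15 log units; within the scatter) for chloro in place of hydrogen and a 1.6-fold lower number from compound 2 to compound 4 (0.20 log units; within the scatter) for 2-chlorophenyl in place of 4-methoxyphenyl.

Still open, on these data alone, is whether a different kind of group on this aromatic ring, such as an amine or a carboxylic acid, or a longer chain between the ring nitrogen and the aromatic ring, would move the number beyond the scatter. Nothing measured here gives a reason for these numbers.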